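Adding a bromo to the benzoyl of compound 3

The source may hold more compounds than are shown below. What is called first, only, known or untested is meant among the compounds shown, and "the series" means these compounds.

Measured in a functional assay on A549 cells (Homo sapiens) for inhibition, read by MTT assay, with a stated time of 24 h; a lower number here means a stronger inhibitor of growth, a higher number a weaker inhibitor of growth:
- Compound 1 `Cn1cc(-c2nc3ccccc3n2C(=O)c2ccccc2)c2ccccc21`: 19600 nM
- Compound 2 `COc1ccc(C(=O)n2c(-c3cn(C)c4ccccc34)nc3ccccc32)cc1OC`: 3100 nM
- Compound 3 `COc1ccc2c(c1)c(-c1nc3ccccc3n1C(=O)c1ccccc1)cn2C`: 16700 nM

Compound 3, at 16700 nM, cannot be told apart from compound 1, and both carry higher numbers than compound 2. Compound 4 `COc1ccc2c(c1)c(-c1nc3ccccc3n1C(=O)c1cccc(Br)c1)cn2C` differs from compound 3 by bromo in place of hydrogen on an aromatic carbon, which turns benzoyl into (3-bromophenyl)carbonyl. The nearest guide is a 6.3-fold lower number from compound 1 to compound 2 (0.80 log units; beyond the scatter), a change on that same phenyl. A methoxy elsewhere gave only a 1.2-fold lower number from compound 1 to compound 3 (0.07 log units; within the scatter). For the measured compounds named here, no measured step involves bromo, so a smaller move in the same direction seems reasonable. The expected change is a 2.1-fold lower number from compound 3 to compound 4 (0.32 log units; beyond the scatter). In this assay, compound 4 is expected at about 8000 nM, with an estimated range of 2500 nM to 22000 nM.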

Compound 4, concentration for 50% growth inhibition: 24800 nM
Compound 4: the middle estimate sits 3.1-fold (0.49 log units) below what was measured; the whole stated range lies below it.
By their numbers in this assay, from the lowest: compound 2; then compounds 3, 1 and 4 (each within the scatter of the next).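

In this assay, bromo in place of hydrogen on the benzoyl of compound 3 gives a 1.5-fold higher number from compound 3 to compound 4 (0.17 log units; within the scatter) and so cannot be told apart from no change. This phenyl therefore does not respond to every group placed on it, since 3,4-dimethoxyphenyl in place of phenyl gave a 6.3-fold lower number from compound 1 to compound 2 (0.80 log units; beyond the scatter) on the core without the extra methoxy. Nothing measured here explains why these two changes differ.

As far as these compounds go, whether a single methoxy or an amine on this phenyl would lower the number remains open. It is also unknown whether 3,4-dimethoxyphenyl would lower it on the core of compound 3.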